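Swapping methoxy for fluoro on compound 2

The source may report more compounds than this note shows. Statements on the series, on what has been measured and on what is new or still open speak of the compounds shown alone.

Compound 1 `CN(C)C(=O)c1cc2cnc(Nc3ccc(N4CCNCC4)cn3)nc2n1Cc1ccccc1`: 30400 nM
Compound 2 `COc1ccccc1NC(=O)c1cc2cnc(Nc3ccc(N4CCNCC4)cn3)nc2n1C1CCCC1`: 1830 nM

In a functional assay on MIA PaCa-2 cells (Homo sapiens) for inhibition, read by MTT assay (on this read-out lower numbers stand for stronger inhibition and higher numbers for weaker inhibition), compound 2 gives 1830 nM, the lower of the two numbers and beyond the scatter of compound 1. Compound 3 `O=C(Nc1ccccc1F)c1cc2cnc(Nc3ccc(N4CCNCC4)cn3)nc2n1C1CCCC1` differs from compound 2 in one place: fluoro in place of methoxy on an aromatic carbon, ortho to a large group (fluoro in place of methoxy on an aromatic carbon). Among the measured compounds shown here, no measured pair shows this kind of change, so the evidence is thin. The expected result in this assay is none beyond the scatter, with a 1.1-fold higher number from compound 2 to compound 3 (0.04 log units; within the scatter) as the estimated step. For compound 3 the estimated value is 2000 nM, with an expected range of 800 nM to 5000 nM.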

Compound 3, half-maximal inhibitory concentration: 3670 nM
Compound 3: the middle estimate sits 1.8-fold (0.26 log units) below what was measured, and the stated range covers the measured number.
By their numbers in this assay, from the lowest: compounds 2 and 3 (each within the scatter of the next); then compound 1.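

In this assay, replacing 2-methoxyphenyl with 2-fluorophenyl gives a 2.0-fold higher number from compound 2 to compound 3 (0.30 log units; within the scatter), so this first pair that differs in one place shows no difference that can be told from the scatter. At this aromatic carbon, the exchange removes a hydrogen-bond acceptor and a heavy atom without a clear shift in the number. Nothing measured here explains this result. Going by these compounds, it remains open whether an amine or a carboxylic acid on that carbon would give a clearly different number. On these data alone, whether the same exchange would behave alike with other groups elsewhere on the shared core also remains open.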